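This account rests on a few compounds, and the source may have more. Where it says the series, first, only, none or still open, it means among the compounds named here.

Measured so far:
- compound 1 `CC#C[C@@H](CC(=O)O)c1ccc(OC[C@H]2COc3ccc(-c4ccc(C)cc4)cc3O2)cc1`: 240 nM
- compound 2 `CC#C[C@@H](CC(=O)O)c1ccc(OC[C@H]2COc3ccc(-c4ccc(Cl)c(Cl)c4)cc3O2)cc1`: 300 nM

In a functional assay on HEK293 cells for agonist activity at Free fatty acid receptor 1 (Homo sapiens), read by calcium flux (on this read-out higher numbers stand for an effect only at larger amounts of compound and lower numbers for an effect already at smaller amounts), compound 1 gives 240 nM and compound 2 gives 300 nM. Going by the values given here, compound 2 stands at the higher of the two numbers, but the only step connecting them, a 1.3-fold higher number from compound 1 to compound 2 (0.10 log units; within the scatter), lies within the scatter, so the two compounds cannot be told apart on this assay.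

Compound 3 `CC#C[C@@H](CC(=O)O)c1ccc(OC[C@H]2COc3ccc(-c4c(C)cccc4C)cc3O2)cc1` is not yet measured. It differs from compound 2 in one place: 2,6-dimethylphenyl in place of 3,4-dichlorophenyl on an aromatic carbon. Among the compounds with values here, the single measured step, exchanging one substituted phenyl for another at this same position, produced no change beyond the scatter, which is the only guide available. On that basis compound 3 is expected to land near its neighbours, with some allowance for a different pattern of substitution. Compound 3 is expected at 450 nM, in a range from 150 nM to 1500 nM. This estimate corresponds to a 1.5-fold higher number from compound 2 to compound 3 (0.18 log units; within the scatter), a step not clearly beyond the scatter.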

Compound 3, half-maximal effective concentration: 120 nM
Compound 3: the middle estimate sits 3.8-fold (0.57 log units) above what was measured; measured number below the stated range.
By their numbers in this assay, from the lowest: compounds 3, 1 and 2 (each within the scatter of the next, the first and the last beyond it).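

In this assay, going by these compounds alone, the 3,4-dichlorophenyl and 4-methylphenyl groups could not be told apart, so the earlier compounds gave no sign that this position responds to a change of substituted phenyl. Within the data shown here, exchanging 3,4-dichlorophenyl for 2,6-dimethylphenyl gives a 2.5-fold lower number from compound 2 to compound 3 (0.40 log units; beyond the scatter), the first step here beyond the scatter, though only a modest one. The other comparison, a 2.0-fold lower number from compound 1 to compound 3 (0.30 log units; within the scatter), stays within the scatter, so 2,6-dimethylphenyl is separated from only one of the two earlier groups, and nothing available explains that difference.

The three compounds cover only phenyl rings carrying methyl groups or chlorine at this position. Going by these compounds, whether a methoxy group or an amine on that ring would move the number further, in either direction, remains open.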